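The compounds below may be only part of what the source reports. "The series", "measured", "known", "first", "only" and "open" are said of these compounds alone.

Measured so far:
- compound 1, `O=C(NC1CCN(Cc2ccn(-c3ccc(C(F)(F)F)cc3)c2)CC1)N1CCCC1Cc1cccnc1`; in an assay on HEK293 cells for displacement of a labelled ligand from melanin-concentrating hormone receptor 1 (Homo sapiens) (on this read-out higher numbers stand for weaker inhibition and lower numbers for stronger inhibition), compound 1 gives 26 nM
- compound 2, `O=C(NC1CCN(Cc2ccn(-c3ccc(C(F)(F)F)cc3)c2)CC1)N1CC[C@@H](O)C1`; in this assay compound 2 gives 138 nM
- compound 3, `O=C(NC[C@@H]1CCCC[C@H]1O)NC1CCN(Cc2ccn(-c3ccc(C(F)(F)F)cc3)c2)CC1`; not yet measured in this assay

Among the compounds with values here, compound 2 stands at the higher of the two numbers so far, weaker than compound 1 by a 5.3-fold higher number from compound 1 to compound 2 (0.72 log units; beyond the scatter). The move from compound 2 to compound 3 is ((2-hydroxycyclohexyl)methyl)amino in place of 3-hydroxypyrrolidin-1-yl on a carbonyl carbon. Within the data shown here, only one measured step touches this part of the molecule, and it shows that what sits on this carbonyl carbon matters: trading the larger pyridinylmethyl-bearing pyrrolidine of compound 1 for the small hydroxypyrrolidine of compound 2 cost a 5.3-fold higher number from compound 1 to compound 2 (0.72 log units; beyond the scatter). Compound 3 keeps a hydroxyl, as compound 2 does, but carries it on a larger six-membered ring attached through a methylene-amino link, so its piece is nearer in bulk to compound 1 than compound 2 is. Among the measured compounds shown here, no measured step tells how the open amino link compares with the ring nitrogen. A modest step is expected, with the direction uncertain but leaning toward a lower number. For compound 3 the estimate is 100 nM, within 30 nM to 400 nM, meaning an expected step of a 1.4-fold lower number from compound 2 to compound 3 (0.14 log units; within the scatter).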

Compound 3, half-maximal inhibitory concentration: 46 nM
For compound 3 the middle estimate is 2.2-fold (0.34 log units) above the measured one; the measured number falls inside the stated range.
By their numbers in this assay, from the lowest: compounds 1 and 3 (each within the scatter of the next); then compound 2.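

In this assay, putting ((2-hydroxycyclohexyl)methyl)amino on the carbonyl carbon in place of 3-hydroxypyrrolidin-1-yl gives a 3.0-fold lower number from compound 2 to compound 3 (0.48 log units; beyond the scatter) and so shows that a hydroxyl-bearing group at this position need not come with the weaker inhibition seen for compound 2. Set against compound 1, the same group gives a 1.8-fold higher number from compound 1 to compound 3 (0.25 log units; within the scatter) on this read-out, so these two cannot be told apart, even though the group in compound 3 has a carbon-only six-membered ring and an open amino link, and no pyridin-3-yl group. Among these compounds, then, the pyridin-3-yl group is not required for inhibition at the level of compound 1, but nothing available explains why these groups differ as they do.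

Ring size, the amino link and the placing of the hydroxyl all change together in this step, so the compounds shown do not tell which of these changes accounts for the difference from compound 2. As far as these compounds go, how a (cyclohexylmethyl)amino group, the same piece without its hydroxyl, would compare remains open, as does the effect of reversing either defined stereocentre of compound 3.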